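The source may hold more compounds than are shown below. What is called first, only, known or untested is meant among the compounds shown, and "the series" means these compounds.

Measured so far:
compound 1 `O=C1C=C(N2CCC2)C(=O)c2c1nc1n2[C@H]2OC[C@@H](O)[C@H]2OC1` – > 16000 nM in a functional assay on HeLa cells (Homo sapiens) for inhibition, read by sulforhodamine B assay; on this read-out lower numbers stand for stronger inhibition and higher numbers for weaker inhibition
compound 2 `Cc1ccc(NC2=CC(=O)c3c(nc4n3[C@H]3OC[C@@H](O)[C@H]3OC4)C2=O)cc1` – 6590 nM
compound 3 `O=C1C=C(Nc2ccc(I)cc2)C(=O)c2c1nc1n2[C@H]2OC[C@@H](O)[C@H]2OC1` – 4070 nM

In this assay compound 1 gives only a limit, (the limit of > 16000 nM in this assay, at which 1 of the 3 values shown sits), and no number. Compound 2 stands highest of the two numbers; compound 3, with 4070 nM, sits within the scatter of it, so no order between compound 2 and compound 3 can be read.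

Compound 4 `O=C1C(NC2CCCCC2)=CC(=O)c2c1nc1n2[C@H]2OC[C@@H](O)[C@H]2OC1` is not yet measured. It differs from compound 2 in one place:
cyclohexyl in place of 4-methylphenyl on an amine nitrogen

Going by the values given here, the only measured step, an at least 3.9-fold lower number from compound 1 to compound 3 (0.59 log units; beyond the scatter), concerns an azetidin-1-yl replaced by a (4-iodophenyl)amino group and does not match the present change; no measured pair compares a saturated ring with an aromatic ring on the amine nitrogen. Among the compounds with values here, what the data show is that the one compound without an aryl group on this position, compound 1, gave only a limit, while both aryl-bearing compounds gave numbers. On that thin basis compound 4 is expected to come out somewhat weaker than compound 2, with the step of a 1.7-fold higher number from compound 2 to compound 4 (0.22 log units; within the scatter) estimated as modest. It is also part of this expectation that compound 4 might end up as only a limit rather than a number. The estimate for compound 4 is 11000 nM, expected between 4000 nM and 30000 nM.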

Compound 4, half-maximal inhibitory concentration: > 16000 nM
Compound 4: a limit, no number; the forecaster's own chance of this, stated with the estimate: 30%; at least 1.4-fold (0.16 log units) between middle value and limit.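

In this assay, going by these compounds alone, cyclohexyl in place of 4-methylphenyl on an amine nitrogen gives an at least 2.4-fold higher number from compound 2 to compound 4 (0.38 log units; beyond the scatter), the first measured step that changes a six-membered aromatic ring of carbon only into a six-membered non-aromatic ring of carbon only on this nitrogen. Compound 4 gives > 16000 nM, which is a limit and not a number, so this step has a lower bound but no measured size. Read together with an at least 3.9-fold lower number from compound 1 to compound 3 (0.59 log units; beyond the scatter), both steps now point the same way, with the compounds carrying an aromatic ring on this nitrogen giving numbers and the two without one sitting at the limit, and no compound shown goes against this: the limit of > 16000 nM in this assay, at which 2 of the 4 values shown sit.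

Still open, as far as these compounds go, is whether a number at this position requires the aromatic ring directly on the amine nitrogen, which a benzylamino or an open-chain butylamino group would test. Also open, from the compounds shown here alone, is how a 4-methoxyphenyl or 4-carboxyphenyl group would stand against 4-methylphenyl, since compound 2 and compound 3 lie within the scatter of each other and give no order for the group on the aromatic ring.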